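The source may report more compounds than this note shows. Statements on the series, on what has been measured and on what is new or still open speak of the compounds shown alone.

Measured in an assay on membranes from brain for displacement of a labelled ligand from Neuronal acetylcholine receptor; alpha4/beta2 (Rattus norvegicus); a higher number here means a weaker inhibitor, a lower number a stronger inhibitor:
Compound 1, `CN1CCC[C@H]1COc1cncc(Cl)c1`, gives 0.6 nM.
Compound 2, `CCc1cncc(OC[C@@H]2CCCN2C)c1`, gives 0.32 nM.
Compound 3, `CCCCc1cncc(OC[C@@H]2CCCN2C)c1`, gives 0.16 nM.

Compound 3 has the lowest of the three numbers: the step to it is a 2.0-fold lower number from compound 2 to compound 3 (0.30 log units; within the scatter) and a 3.8-fold lower number from compound 1 to compound 3 (0.57 log units; beyond the scatter), only the latter lying beyond the scatter. Compound 4, `CCCCCCc1cncc(OC[C@@H]2CCCN2C)c1`, differs from compound 3 by ethyl in place of hydrogen on a saturated chain carbon, four bonds along the chain from an aromatic carbon. The step that bears most directly on this change is a 2.0-fold lower number from compound 2 to compound 3 (0.30 log units; within the scatter), the same addition made on a saturated chain carbon two bonds along the chain from an aromatic carbon; a 1.9-fold lower number from compound 1 to compound 2 (0.27 log units; within the scatter) and a 3.8-fold lower number from compound 1 to compound 3 (0.57 log units; beyond the scatter) point the same way. The expected step is therefore a 1.6-fold lower number from compound 3 to compound 4 (0.20 log units; within the scatter), a small further lowering at most, possibly none beyond the scatter. Compound 4 is accordingly estimated at 0.1 nM, with a range from 0.04 nM to 0.3 nM.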

Compound 4, inhibition constant: 0.32 nM
Beside the measured number, compound 4's estimate is 3.2-fold (0.51 log units) below it; measured number above the stated range.
By their numbers in this assay, from the lowest: compounds 3, 2, 4 and 1 (each within the scatter of the next, the first and the last beyond it).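

In this assay, ethyl added four bonds along the chain from an aromatic carbon gives a 2.0-fold higher number from compound 3 to compound 4 (0.30 log units; within the scatter) and so does not extend the run of lower numbers to hexyl. Butyl added to the ethyl group gives no change at the digits printed from compound 2 to compound 4 (within the scatter) and hexyl in place of chloro gives a 1.9-fold lower number from compound 1 to compound 4 (0.27 log units; within the scatter), so hexyl, unlike butyl, does not stand beyond the scatter of chloro. No measurement at hand accounts for this result.

On these data alone, whether a longer chain such as octyl, or a chain carrying an amine or a carboxylic acid, would hold this level remains open.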